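A few compounds are considered here, and "the series" means these few. Any claim that something is new, unique, unknown or untested is made for them only; others in the source may bear on it.

Measured in a functional assay on MV4-11 cells (Homo sapiens) for antiproliferative activity, read by CCK-8 assay, with a stated time of 72 h; a higher number here means a weaker inhibitor, a lower number a stronger inhibitor:
- Compound 1 `Cn1cc(-c2ccccc2Oc2ccccc2)c2cc(C(=O)NCc3ccc(C(=O)Nc4ccccc4N)cc3)[nH]c2c1=O`: 80 nM
- Compound 2 `Cn1cc(-c2cccc(F)c2)c2cc(C(=O)NCc3ccc(C(=O)Nc4ccccc4N)cc3)[nH]c2c1=O`: 210 nM

Compound 2, at 210 nM, has the higher of the two numbers, so it is the weaker inhibitor of the pair. Compound 1, at 80 nM, has the lower number, and the gap between the two lies beyond the usual scatter of repeated measurements.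

Compound 3 `Cc1ccccc1-c1cn(C)c(=O)c2[nH]c(C(=O)NCc3ccc(C(=O)Nc4ccccc4N)cc3)cc12` has not yet been measured. It departs from compound 2 in one place: 2-methylphenyl in place of 3-fluorophenyl on an aromatic carbon. Put simply, 2-methylphenyl stands in place of 3-fluorophenyl on an aromatic carbon. Within the data shown here, no measured pair shows this swap, so the data offer no direct guide to its effect.

The only measured range runs from compound 1 at 80 nM to compound 2 at 210 nM, and compound 3 is expected to fall near or within it. In this assay, a slightly lower number is expected, but no step beyond the scatter. The expected change is a 1.4-fold lower number from compound 2 to compound 3 (0.15 log units; within the scatter). For compound 3 the estimate is 150 nM, with an expected range of 60 nM to 400 nM.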

Compound 3, half-maximal inhibitory concentration: 310 nM
Beside the measured number, compound 3's estimate is 2.1-fold (0.32 log units) below it; measured number inside the range.
By their numbers in this assay, from the lowest: compound 1; then compounds 2 and 3 (each within the scatter of the next).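

In this assay, putting 2-methylphenyl in place of 3-fluorophenyl on this aromatic carbon of the shared core gives a 1.5-fold higher number from compound 2 to compound 3 (0.17 log units; within the scatter), so this swap produces no change that can be told apart from the scatter. The comparison with compound 1 adds a clearer signal: methyl in place of phenoxy on an aromatic carbon gives a 3.9-fold higher number from compound 1 to compound 3 (0.59 log units; beyond the scatter), a step beyond the scatter, showing that this assay can register a change in the group carried by the attached phenyl ring. No independent measurement among the data shown explains either step.

From the compounds shown here alone, it remains open whether an amine, a carboxylic acid or a longer chain in place of the methyl of compound 3 would give a number closer to that of compound 1 or stay near that of compound 3. It is also unresolved how much the identity of a group and its place on the phenyl ring each contribute, as 3-fluorophenyl and 2-methylphenyl differ in both.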